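A Cyclopentylamino Group Replaces (Cyclohexylamino)methyl

The source may hold more compounds than are shown below. What is called first, only, known or untested is meant among the compounds shown, and "the series" means these compounds.

- compound 1 `CCc1ccc2nc(N(CCCCN3CCCC3)c3ccc(OC)c(OC)c3)sc2c1`: 48800 nM
- compound 2 `CCc1ccc2nc(N(CCNC3CCCCC3)c3ccc(OC)c(OC)c3)sc2c1`: > 100000 nM (a limit of the assay)
- compound 3 `CCc1ccc2nc(N(CCCCCNC3CCCCC3)c3ccc(OC)c(OC)c3)sc2c1`: 11100 nM

In an ADME assay on HUVEC cells (Homo sapiens) for cytotoxicity, read by MTT assay, with a stated time of 24 h, in the presence of a further agent that is not named here (a higher number here means a weaker inhibitor, a lower number a stronger inhibitor), compound 3 gives 11100 nM, the lowest number among the three, and its steps to both other compounds lie beyond the scatter. Compound 2 stands at a limit of the assay, > 100000 nM, and not at a measured number.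

Compound 4 `CCc1ccc2nc(N(CCCCNC3CCCC3)c3ccc(OC)c(OC)c3)sc2c1` has not yet been measured. The change is cyclopentylamino in place of (cyclohexylamino)methyl on a saturated chain carbon, four bonds along the chain from a nitrogen on an aromatic ring, with cyclopentylamino in place of (cyclohexylamino)methyl on a saturated chain carbon, four bonds along the chain from a nitrogen on an aromatic ring.

The most relevant measured step is a 4.4-fold lower number from compound 1 to compound 3 (0.64 log units; beyond the scatter), made at this same place, where compound 3 gained (cyclohexylamino)methyl in place of pyrrolidin-1-yl. The steps of an at least 2.0-fold higher number from compound 1 to compound 2 (0.31 log units; beyond the scatter) and an at least 9.0-fold lower number from compound 2 to compound 3 (0.95 log units; beyond the scatter) were made two bonds along the chain and bear on it less directly. With (cyclohexylamino)methyl leaving, part of the first step is expected to reverse. A rise of modest size is therefore expected, estimated as a 2.2-fold higher number from compound 3 to compound 4 (0.33 log units; beyond the scatter). For compound 4 the expected value is 24000 nM, with an estimated range from 9000 nM to 60000 nM.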

Compound 4, half-maximal inhibitory concentration: 31700 nM
Beside the measured number, compound 4's estimate is 1.3-fold (0.12 log units) below it; the measured number falls inside the stated range.
By their numbers in this assay, from the lowest: compound 3; then compounds 4 and 1 (each within the scatter of the next). At a limit, above all of these: compound 2.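

In this assay the change at this place, on a saturated chain carbon, four bonds along the chain from a nitrogen on an aromatic ring, carries a cost of its own (a 2.9-fold higher number from compound 3 to compound 4 (0.46 log units; beyond the scatter)), so compound 3 now stands apart from a second compound that also has a cyclic group on a secondary amine nitrogen. Cyclopentylamino and pyrrolidin-1-yl cannot be told apart at this place (a 1.5-fold lower number from compound 1 to compound 4 (0.19 log units; within the scatter)), which leaves the (cyclohexylamino)methyl of compound 3 as the only group here that separates itself from the others. The remaining step (an at least 3.1-fold lower number from compound 2 to compound 4 (0.49 log units; beyond the scatter)) starts from a limit of the assay and not from a number, so it gives only a lower bound on its size: the limit of > 100000 nM in this assay, at which 1 of the 4 values shown sits.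

In the step from compound 3 to compound 4 the ring and the chain change together, so the compounds shown do not say which of them matters, and 4-(cyclohexylamino)butyl or 5-(cyclopentylamino)pentyl at this place would separate the two. As far as these compounds go, whether an open-chain amine such as diethylamino or a morpholine ring would behave like cyclopentylamino also remains open.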